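Pyrrolidine amides: cyclohexyloxy to phenoxy at the aromatic carbon

A few compounds are considered here, and "the series" means these few. Any claim that something is new, unique, unknown or untested is made for them only; others in the source may bear on it.

Compound 1 `O=C(CCc1ccc(-c2ccc(F)cc2)cc1)N1CCCC1`: 3400 nM
Compound 2 `O=C(CCc1ccc(-c2cccs2)cc1)N1CCCC1`: > 100000 nM
Compound 3 `O=C(CCc1ccc(OC2CCCCC2)cc1)N1CCCC1`: 700 nM

In an assay on HEK293 cells for inhibition of N-acylethanolamine-hydrolyzing acid amidase (Rattus norvegicus), read by LC-MS, with a stated time of 30 min (a higher number here means a weaker inhibitor, a lower number a stronger inhibitor), compound 3 gives the lowest of the two numbers, with compound 1 nearest at a 4.9-fold lower number from compound 1 to compound 3 (0.69 log units; beyond the scatter). Compound 2 sits at the limit of this assay, (the limit of > 100000 nM in this assay, at which 1 of the 3 values shown sits). Compound 4 `O=C(CCc1ccc(Oc2ccccc2)cc1)N1CCCC1` carries phenyl in place of cyclohexyl on an oxygen on an aromatic ring. Among the compounds with values here, no measured step changes a group on the oxygen; the steps seen, a 4.9-fold lower number from compound 1 to compound 3 (0.69 log units; beyond the scatter) and an at least 29-fold higher number from compound 1 to compound 2 (1.46 log units; beyond the scatter), swap the whole substituent on the aromatic carbon and so bear on it only loosely. A small step in this assay, if any, is expected, most likely toward a higher number, a 2.1-fold higher number from compound 3 to compound 4 (0.33 log units; beyond the scatter). Compound 4 is therefore estimated at 1500 nM, within 400 nM to 6000 nM.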

Compound 4, half-maximal inhibitory concentration: > 100000 nM
Compound 4: a limit, no number; the forecaster's own chance of this, stated with the estimate: 10%; middle value at least 66-fold (1.82 log units) away from the limit.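

Phenyl in place of cyclohexyl on the oxygen is the first measured change to this group alone, and in this assay it gives an at least 140-fold higher number from compound 3 to compound 4 (2.15 log units; beyond the scatter). Phenoxy also falls behind 4-fluorophenyl, with an at least 29-fold higher number from compound 1 to compound 4 (1.46 log units; beyond the scatter), so the oxygen alone does not carry the gain seen for compound 3. Compound 2 and compound 4 both stand at a limit, and the step between them cannot be read: the limit of > 100000 nM in this assay, at which 2 of the 4 values shown sit.

From the compounds shown here alone, how far compound 4 lies past its limit stays open. Also open, going by these compounds, is whether cyclopentyl or a piperidine ring on the oxygen would keep the number of compound 3.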